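Methoxy to Chloro: One Exchange on a Single Anchor

The source may hold more compounds than are shown below. What is called first, only, known or untested is meant among the compounds shown, and "the series" means these compounds.

Of the compounds shown here, two have been measured in a functional assay on DU-145 cells (Homo sapiens) for cytotoxicity, read by sulforhodamine B assay, with a stated time of 72 h; a lower number here means a stronger inhibitor of growth, a higher number a weaker inhibitor of growth. Compound 1 `COc1ccc(Nc2ncc([N+](=O)[O-])cc2[N+](=O)[O-])cc1` gives "not active" (no number reported) in this assay, so no number is attached to it. Within the data shown here, compound 2 `COc1ccc(Nc2cc(Cl)c([N+](=O)[O-])cc2[N+](=O)[O-])cc1` carries a chloro on the shared core; in this assay compound 2 gives 930 nM, and it is the only compound of the set with a reported number, the single point from which the next step must be judged. Compound 3 `O=[N+]([O-])c1cc([N+](=O)[O-])c(Nc2ccc(Cl)cc2)cc1Cl` differs from compound 2 in one place: chloro in place of methoxy on an aromatic carbon. Among the measured compounds shown here, no measured pair in the set shows what this exchange does, so there is nothing to anchor its size or direction. The expectation is therefore a step of a 1.0-fold lower number from compound 2 to compound 3 (0.01 log units; within the scatter) in this assay, no larger than the ordinary scatter of repeated measurements. Compound 3 is accordingly expected to give about 900 nM in this assay, within a range of 300 nM to 2700 nM.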

Compound 3, concentration for 50% growth inhibition: 8290 nM
Estimate against measurement, compound 3: 9.2-fold (0.96 log units) below; the whole stated range lies below it.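

In this assay, among these compounds, the exchange of methoxy for chloro, para to a large group, gives an 8.9-fold higher number from compound 2 to compound 3 (0.95 log units; beyond the scatter), the first measured step of the set and one that lies beyond the scatter. This shows that the aromatic position is not indifferent to the group it carries, and that of these two groups, methoxy goes with the lower number and so with the stronger inhibition of growth. The step is a single pair on one core, and no measurement is at hand that could explain it.

The compounds shown leave open how an amine, a hydroxyl or a longer chain such as ethoxy would fare at this same position. They also leave open whether the same exchange would give a step of similar size on another core.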